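Amine size and affinity in the chloro-biaryl series

The source may hold more compounds than are shown below. What is called first, only, known or untested is meant among the compounds shown, and "the series" means these compounds.

For the measured compounds named here, compound 3 `CNCc1ccc(Cl)c(-c2ccccc2OC)c1` is the only member of this set with a number in an assay on isolated protein for binding affinity to 5-hydroxytryptamine receptor 6 (Homo sapiens); on this read-out higher numbers stand for weaker inhibition and lower numbers for stronger inhibition: compound 3 gives 1300 nM. Compound 1 `CCCN(CCC)Cc1ccc(Cl)c(-c2ccccc2OC)c1` returns only a limit, > 10000 nM. Compound 2 `COc1ccccc1-c1cc(C2CCN(C)C2)ccc1Cl` likewise returns only a limit, > 10000 nM. Both steps toward compound 3 were sizeable: an at least 7.6-fold lower number from compound 1 to compound 3 (0.88 log units; beyond the scatter) and an at least 7.6-fold lower number from compound 2 to compound 3 (0.88 log units; beyond the scatter). Compound 4 `CCCCNCc1ccc(Cl)c(-c2ccccc2OC)c1` carries propyl in place of hydrogen on a saturated chain carbon bound to an amine nitrogen. The step that bears on it is an at least 7.6-fold lower number from compound 1 to compound 3 (0.88 log units; beyond the scatter), where dipropylamino became methylamino and the number fell at least modestly; the move to butylamino runs the other way. A higher number in this assay is therefore expected for compound 4, a 3.1-fold higher number from compound 3 to compound 4 (0.49 log units; beyond the scatter). Compound 4 is estimated at 4000 nM, within 1500 nM to 15000 nM, and a limit would not surprise because the limit of > 10000 nM in this assay, at which 2 of the 3 values shown sit, already holds two of three values.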

Compound 4, inhibition constant: 240 nM
Beside the measured number, compound 4's estimate is 17-fold (1.22 log units) above it; the whole stated range lies above it.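

Lengthening methylamino to butylamino lowers the number in this assay, with a 5.4-fold lower number from compound 3 to compound 4 (0.73 log units; beyond the scatter), so the earlier drop from dipropylamino to methylamino cannot be read as a simple preference for the smaller amine. The steps from the two compounds with limits are larger, with an at least 41-fold lower number from compound 1 to compound 4 (1.61 log units; beyond the scatter) and an at least 41-fold lower number from compound 2 to compound 4 (1.61 log units; beyond the scatter), but both are only bounds resting on a limit: the limit of > 10000 nM in this assay, at which 2 of the 4 values shown sit.

As far as these compounds go, whether the number keeps falling with a longer chain such as hexylamino remains open. So does the outcome with a branched isobutylamino or a ring-bearing benzylamino in place of butylamino.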